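Aryl swap on the shared core, read for cytotoxicity

A few compounds are considered here, and "the series" means these few. Any claim that something is new, unique, unknown or untested is made for them only; others in the source may bear on it.

Measured in a functional assay on HL-60 cells (Homo sapiens) for cytotoxicity, read by CellTiter-Blue, with a stated time of 48 h; on this read-out higher numbers stand for weaker inhibition and lower numbers for stronger inhibition:
- compound 1 `COc1cc(OC)cc(-c2ccc3c(c2)C(CC(=O)OCC2CO2)C(C(=O)OCC2CO2)=C(N)O3)c1`: > 80000 nM (a limit)
- compound 2 `CCOC(=O)CC1C(C(=O)OCC)=C(N)Oc2ccc(-c3ccco3)cc21`: > 80000 nM (a limit)

Compound 2 gives only a limit, > 80000 nM, and not a number. Among the measured compounds shown here, the whole series so far rests on (the limit of > 80000 nM in this assay, at which 2 of the 2 values shown sit). Compound 3 `CCOC(=O)CC1C(C(=O)OCC)=C(N)Oc2ccc(-c3cccc(N)c3)cc21` replaces furan-2-yl of compound 2 with 3-aminophenyl on an aromatic carbon: 3-aminophenyl in place of furan-2-yl on an aromatic carbon. For the measured compounds named here, no step between measured compounds is available to size this change. In this assay, a modest move toward stronger inhibition is expected, though a further limit is quite possible. The estimated step is an at least 2.0-fold lower number from compound 2 to compound 3 (0.30 log units; that floor lies within the scatter). For compound 3 the expected value is 40000 nM, with an estimated range of 10000 nM to 80000 nM.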

Compound 3, half-maximal inhibitory concentration: 20200 nM
Compound 3: middle estimate off by 2.0-fold (0.30 log units), on the high side, within the range that was stated.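

The aryl position on the shared core can shift this assay at all: 3-aminophenyl in place of furan-2-yl gives an at least 3.9-fold lower number from compound 2 to compound 3 (0.59 log units; beyond the scatter) and leaves compound 3 with a number rather than a limit. The size of this step remains a floor, and most of the series still sits at one limit: the limit of > 80000 nM in this assay, at which 2 of the 3 values shown sit.

The swap changes the ring and adds the amine together, so the compounds shown do not separate the two. From the compounds shown here alone, whether a plain phenyl or a 3-carboxyphenyl at this position would give a number remains open.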